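The source may hold more compounds than are shown below. What is called first, only, known or untested is meant among the compounds shown, and "the series" means these compounds.

Measured compounds:
- compound 1, `CCn1c(=O)[nH]c(=O)c2[nH]c(-c3cnn(Cc4ccccc4)c3)nc21`: "not determined" (no result reported) in an assay on CHO cells for displacement of a labelled ligand from adenosine receptor A3 (Homo sapiens); on this read-out lower numbers stand for stronger inhibition and higher numbers for weaker inhibition
- compound 2, `CCCn1c(=O)[nH]c2nc(-c3cnn(Cc4ccccc4)c3)[nH]c2c1=O`: 120 nM
- compound 3, `CCCn1c(=O)[nH]c2nc(-c3cnn(Cc4cccc(F)c4)c3)[nH]c2c1=O`: 160 nM

Among the measured compounds shown here, only two numbers exist in this assay. For the measured compounds named here, compound 3 gives 160 nM, the higher of the two, but its only neighbour, compound 2, sits close: the step of a 1.3-fold higher number from compound 2 to compound 3 (0.12 log units; within the scatter) is within the scatter, so no order between compound 2 and compound 3 can be read. Compound 1 carries a different chain on the core and has no number.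

The next compound, compound 4, `CC(C)Cn1c(=O)[nH]c2nc(-c3cnn(Cc4cccc(F)c4)c3)[nH]c2c1=O`, keeps the fluoro-substituted benzyl of compound 3 and changes the chain on the core: methyl in place of hydrogen on a saturated chain carbon bound to two saturated chain carbons. Going by the values given here, no measured step touches this chain; the one step recorded, fluoro for hydrogen, concerns the other end of the molecule, and the shorter-chain compound 1 has no value to compare. There is therefore no basis for expecting a shift beyond the scatter in this assay, in either direction. Compound 4 is estimated at 170 nM, range 60 nM to 480 nM, which means an expected step of a 1.1-fold higher number from compound 3 to compound 4 (0.03 log units; within the scatter).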

Compound 4, inhibition constant: 1600 nM
Estimate against measurement, compound 4: 9.4-fold (0.97 log units) below; measured number above the stated range.
By their numbers in this assay, from the lowest: compounds 2 and 3 (each within the scatter of the next); then compound 4.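

In this assay the chain on the core proves to be a sensitive position: going from propyl to isobutyl, methyl in place of hydrogen on a saturated chain carbon bound to two saturated chain carbons, gives a 10-fold higher number from compound 3 to compound 4 (1.00 log units; beyond the scatter) and so separates compound 4 from the other two values. Among the compounds shown here, the one earlier step, a 1.3-fold higher number from compound 2 to compound 3 (0.12 log units; within the scatter), lay at the benzyl end and showed no such shift, so this is the first change that moves the number beyond the scatter. No data shown bear on the reason for this shift.

Going by these compounds, whether a straight butyl chain on the core would stay close to compound 3 or fall near compound 4 remains open. Also open, on these data alone, is whether the same methyl step holds with the unsubstituted benzyl of compound 2.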